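Swapping the 2,4-dichlorophenyl group of compound 2

The compounds below may be only part of what the source reports. "The series", "measured", "known", "first", "only" and "open" are said of these compounds alone.

Compound 1 `Nc1nc2ccc(-c3cn([C@@H]4CN[C@H](C(=O)Nc5ccc(Cl)c(C(F)(F)F)c5)C4)nn3)nc2s1`: 187000 nM
Compound 2 `O=C(Nc1nc2ccc(-c3cn([C@@H]4CN[C@H](C(=O)Nc5ccc(Cl)cc5Cl)C4)nn3)nc2s1)C1CC1`: 2440 nM

Both values come from a functional assay on K562/Adr cells (Homo sapiens) for inhibition, read by MTT assay, with a stated time of 48 h; on this read-out higher numbers stand for weaker inhibition and lower numbers for stronger inhibition. Compound 2, at 2440 nM, has the lower of the two numbers, and its gap to compound 1 lies well beyond the scatter of repeated measurements. Compound 3 `O=C(Nc1nc2ccc(-c3cn([C@@H]4CN[C@H](C(=O)Nc5ccc(Br)cc5)C4)nn3)nc2s1)C1CC1` has not yet been measured. It differs from compound 2 in one place: 4-bromophenyl in place of 2,4-dichlorophenyl on an amide-type nitrogen. In words, 4-bromophenyl stands in place of 2,4-dichlorophenyl on an amide-type nitrogen.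

Within the data shown here, no measured pair shows this change alone, so the data offer no direct guide to its size. The best anchor is compound 2 at 2440 nM, which shares everything else with the new molecule. A modest loss is expected, with the estimated step being a 2.3-fold higher number from compound 2 to compound 3 (0.35 log units; beyond the scatter), toward weaker inhibition. The expected value for compound 3 is 5500 nM, with an estimated range from 1500 nM to 20000 nM.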

Compound 3, half-maximal inhibitory concentration: 48300 nM
Estimate against measurement, compound 3: 8.8-fold (0.94 log units) below; measured number above the stated range.
By their numbers in this assay, from the lowest: compound 2; then compound 3; then compound 1.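

In this assay the aromatic ring on the amide-type nitrogen proves to matter a great deal: 4-bromophenyl in place of 2,4-dichlorophenyl gives a 20-fold higher number from compound 2 to compound 3 (1.30 log units; beyond the scatter) and so weakens inhibition. The earlier compounds shown here could not show this, as they differ in more than one place, whereas here the rest of the molecule stays the same and the whole step belongs to this single exchange. Nothing at hand says why the step is so large.

This one pair cannot separate the loss of one chlorine from the exchange of the other chlorine for bromine. On these data alone, whether a 4-chlorophenyl group would land nearer compound 2 or compound 3 stays open, as does the result with an unsubstituted phenyl or a 4-methoxyphenyl group on this nitrogen.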